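The source may report more compounds than this note shows. Statements on the series, on what has been measured and on what is new or still open speak of the compounds shown alone.

Measured so far:
compound 1, `Oc1ccc(-c2cc(-c3ccc(Cl)cc3)nc(-c3cccs3)c2)cc1`, with 4520 nM;
compound 2, `Oc1ccc(-c2cc(-c3cccc(Cl)c3)nc(-c3cccs3)c2)cc1`, with 2720 nM;
compound 3, `Oc1cccc(-c2cc(-c3ccc(Cl)cc3)nc(-c3ccsc3)c2)c1`, with 11200 nM.

The numbers come from an ADME assay on HEK293 cells (Homo sapiens) for cytotoxicity, read by CCK-8 assay and cell counting, with a stated time of 2 days; on this read-out higher numbers stand for weaker inhibition and lower numbers for stronger inhibition. Compounds 1 and 2 share a core and differ only in one change, (3-chlorophenyl in place of 4-chlorophenyl on an aromatic carbon), which gave a 1.7-fold lower number from compound 1 to compound 2 (0.22 log units; within the scatter). Compound 3 sits on a different core; how the two cores differ is not broken down here. Compound 3 has the highest number of the three.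

Compound 4, `Oc1cccc(-c2cc(-c3ccsc3)nc(-c3cccc(Cl)c3)c2)c1`, is not yet measured. It arises from compound 3 by 3-chlorophenyl in place of 4-chlorophenyl on an aromatic carbon. Among the measured compounds shown here, this is the same kind of change as the one from compound 1 to compound 2, though the surroundings differ: in compound 3 the place is meta to a 3-hydroxyphenyl group and meta to a thiophen-3-yl group, whereas in compound 1 it is meta to a 4-hydroxyphenyl group and meta to a thiophen-2-yl group.

Because the earlier change gave a 1.7-fold lower number from compound 1 to compound 2 (0.22 log units; within the scatter), compound 4 is expected to show a step of about a 1.5-fold lower number from compound 3 to compound 4 (0.17 log units; within the scatter) in this assay. Compound 4 is thus estimated at 7500 nM, likely between 3000 nM and 20000 nM.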

Compound 4, half-maximal inhibitory concentration: 3180 nM
Beside the measured number, compound 4's estimate is 2.4-fold (0.37 log units) above it, within the range that was stated.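

Putting 3-chlorophenyl in place of 4-chlorophenyl gives a 3.5-fold lower number from compound 3 to compound 4 (0.55 log units; beyond the scatter) in this assay. Set beside the same change on the other core, the two steps run in the same direction, and the gap between them is no larger than repeated measurements could produce: the same change on two cores in this assay, a 1.7-fold lower number (0.22 log units; within the scatter) from compound 1 to compound 2 and a 3.5-fold lower number (0.55 log units; beyond the scatter) from compound 3 to compound 4, 2.1-fold (0.33 log units) apart, within the scatter of two such steps. This suggests that the change carries over between these two cores, with a lower number each time, but two pairs of compounds cannot establish a rule for the whole series, and only the newer step on its own lies beyond the scatter.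

Going by these compounds, it remains open whether the step would hold on cores in which the hydroxyphenyl or thiophene groups are replaced, for example by a phenyl ring bearing a carboxylic acid. On these data alone, it is also open how a phenyl ring bearing an amine or a longer carbon chain in place of the chlorine would read in this assay.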